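Swapping chloro and methyl on the anilino ring

The source may hold more compounds than are shown below. What is called first, only, known or untested is meant among the compounds shown, and "the series" means these compounds.

Compound 1 `Cc1ccc(Nc2ncc(C(F)(F)F)c(N3Cc4cccc(N(C)S(C)(=O)=O)c4C3)n2)c(Cl)c1` was tested in a functional assay on HepG2 cells (Homo sapiens) for antiproliferative activity, read by spectrophotometry, with a stated time of 2 days; on this read-out lower numbers stand for stronger inhibition of growth and higher numbers for weaker inhibition of growth. In this assay compound 1 gives only a limit, > 30000 nM, so no number is known for it. Compound 2 `CN(c1cccc2c1CN(c1nc(Nc3cccc(Oc4ccccc4)c3)ncc1C(F)(F)F)C2)S(C)(=O)=O` gives 23000 nM in this assay. Compound 1 thus stands at the limit of > 30000 nM in this assay, at which 1 of the 2 values shown sits. Compound 3 `Cc1cc(Cl)ccc1Nc1ncc(C(F)(F)F)c(N2Cc3cccc(N(C)S(C)(=O)=O)c3C2)n1` differs from compound 1 by 4-chloro-2-methylphenyl in place of 2-chloro-4-methylphenyl on a nitrogen on an aromatic ring. Within the data shown here, no measured pair shows such a change, so a step of no size beyond the scatter is expected, and a limit is again likely. Compound 3 is estimated at 30000 nM, between 10000 nM and 100000 nM. The expected step is a number no higher from compound 1 to compound 3 (the limit leaves the size open).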

Compound 3, concentration for 50% growth inhibition: 19600 nM
Compound 3: middle estimate off by 1.5-fold (0.18 log units), on the high side; measured number inside the range.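

Exchanging 2-chloro-4-methylphenyl for 4-chloro-2-methylphenyl on a nitrogen on an aromatic ring, with the same atoms joined differently, gives in this assay an at least 1.5-fold lower number from compound 1 to compound 3 (0.18 log units; that floor lies within the scatter). Rearranging these atoms alone is thus enough to turn a limit into a measured number. The true size of the step stays unknown because compound 1 gives only a limit: the limit of > 30000 nM in this assay, at which 1 of the 3 values shown sits.

The compounds shown leave open whether the chloro or the methyl matters more in this exchange. They also leave open whether a fluoro or a methoxy group in place of the chloro would move the number beyond the scatter.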